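The compounds below may be only part of what the source reports. "The series", "measured", "known", "first", "only" and "open" are said of these compounds alone.

In a functional assay (Nicotiana tabacum) (on this read-out lower numbers stand for stronger inhibition and higher numbers for weaker inhibition), three compounds with a shared core have been measured, and they differ only in the group on a nitrogen on an aromatic ring. Compound 3 `CSc1nc(NC2CCCCC2)c2cccnc2n1`, with cyclohexyl there, gives 5650 nM. Compound 1 `CNc1nc(SC)nc2ncccc12`, with methyl, gives 2920 nM, and the two cannot be separated, with a 1.9-fold higher number from compound 1 to compound 3 (0.29 log units; within the scatter). Compound 2 `CSc1nc(NC2CCCC2)c2cccnc2n1`, with cyclopentyl, gives 490 nM and stands apart from both, with a 6.0-fold lower number from compound 1 to compound 2 (0.78 log units; beyond the scatter) and a 12-fold higher number from compound 2 to compound 3 (1.06 log units; beyond the scatter).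

Compound 4 `COCCNc1nc(SC)nc2ncccc12` has 2-methoxyethyl in place of cyclohexyl, (2-methoxyethyl in place of cyclohexyl on a nitrogen on an aromatic ring). Among the measured compounds shown here, no measured step introduces this group, so the evidence is indirect. Compound 1 shows that a much smaller group than cyclohexyl need not shift the number, with a 1.9-fold higher number from compound 1 to compound 3 (0.29 log units; within the scatter), while compound 2 shows that a modest change of group can matter, with a 12-fold higher number from compound 2 to compound 3 (1.06 log units; beyond the scatter). The expected step is therefore small, a 1.9-fold lower number from compound 3 to compound 4 (0.27 log units; within the scatter), and no larger than the scatter. For compound 4 the estimated value is 3000 nM, with an expected range from 800 nM to 10000 nM.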

Compound 4, half-maximal inhibitory concentration: 2530 nM
Compound 4: the middle estimate sits 1.2-fold (0.07 log units) above what was measured; the range from low to high includes it.
By their numbers in this assay, from the lowest: compound 2; then compounds 4, 1 and 3 (each within the scatter of the next, the first and the last beyond it).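

In this assay, replacing cyclohexyl with 2-methoxyethyl moves the number just past the scatter (a 2.2-fold lower number from compound 3 to compound 4 (0.35 log units; beyond the scatter)), while compound 4 cannot be told apart from compound 1, which carries methyl (a 1.2-fold lower number from compound 1 to compound 4 (0.06 log units; within the scatter)). An open chain with one hydrogen-bond acceptor on this nitrogen therefore stays well short of the cyclopentyl group (a 5.2-fold higher number from compound 2 to compound 4 (0.71 log units; beyond the scatter)), and compound 2 remains the only one of the four set apart from all the others. Nothing available explains why these groups differ.

On these data alone, what the oxygen of the 2-methoxyethyl group contributes stays open, and a plain butyl chain in its place would speak to that. As far as these compounds go, how narrowly the low number is tied to cyclopentyl also stays open, and cyclobutyl or cycloheptyl on the same nitrogen would test it.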